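This account rests on a few compounds, and the source may have more. Where it says the series, first, only, none or still open, it means among the compounds named here.

Measured compounds:
compound 1, `CCC1(CCCCCN2CCN(c3cccc(Cl)c3)CC2)C(=O)Nc2ccccc21`, 1.45 nM
compound 2, `CCC1(CCCCN2CCN(c3cccc(OC)c3)CC2)C(=O)Nc2ccccc21`, 2.55 nM

Both compounds were tested in an assay on CHO cells for displacement of a labelled ligand from 5-hydroxytryptamine receptor 7 (Homo sapiens); on this read-out higher numbers stand for weaker inhibition and lower numbers for stronger inhibition. Compound 2 has the higher of the two numbers, but compound 1 sits so close to it that the two values are indistinguishable within the usual scatter; nothing can be said about an order between them.

Compound 3, `CCC1(CCCCN2CCN(c3ccc(C)c(Cl)c3)CC2)C(=O)Nc2ccccc21`, has not been measured. It differs from compound 2 in one place: 3-chloro-4-methylphenyl in place of 3-methoxyphenyl on an amine nitrogen in a ring. Going by the values given here, no step between two measured compounds describes this change, so the expectation rests on the two values at hand. Since compound 1, which carries a 3-chlorophenyl group on the same ring nitrogen, gives 1.45 nM, the step from compound 2 to compound 3 is estimated as a 1.4-fold lower number from compound 2 to compound 3 (0.15 log units; within the scatter), that is, no change beyond the scatter or a slight move to lower numbers. Compound 3 is therefore expected to give about 1.8 nM, with a likely range from 0.6 nM to 6 nM.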

Compound 3, inhibition constant: 0.66 nM
The estimate for compound 3 lay 2.7-fold (0.44 log units) above the measured number; the range from low to high includes it.
By their numbers in this assay, from the lowest: compound 3; then compounds 1 and 2 (each within the scatter of the next).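

In this assay, putting 3-chloro-4-methylphenyl in place of 3-methoxyphenyl on the ring nitrogen gives a 3.9-fold lower number from compound 2 to compound 3 (0.59 log units; beyond the scatter) and so shows that this position responds to the choice of aryl group. Compound 1 and compound 2 differ in both the chain and the aryl group, so they could not show this; here the rest of the molecule stays the same. The swap keeps the count of heavy atoms at 8 while replacing the oxygen with a chlorine and dropping the one hydrogen-bond acceptor. Nothing shown here explains why the number falls with this change.

It stays open whether the chlorine, the methyl or the two together account for the step, as no compound shown has only one of them on the chain of compound 2. The compounds also leave open how a nitrile or a trifluoromethyl group on this phenyl ring would read.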